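A few compounds are considered here, and "the series" means these few. Any claim that something is new, unique, unknown or untested is made for them only; others in the source may bear on it.

Measured so far in an assay on microsomes from liver for inhibition of 3-hydroxy-3-methylglutaryl-coenzyme A reductase (Rattus norvegicus); a lower number here means a stronger inhibitor, a higher number a weaker inhibitor:
compound 1 `CC(C)c1c(C(=O)N(C)Cc2ccccc2)nn(-c2ccc(F)cc2)c1CC[C@@H](O)C[C@@H](O)CC(=O)O` — 6.2 nM
compound 2 `CC(C)c1c(C(=O)N2CCCC2c2ccccc2)nn(-c2ccc(F)cc2)c1OC[C@@H](O)C[C@@H](O)CC(=O)O` — 14 nM

Of the two measured compounds, compound 2 gives the higher number in this assay; compound 1 is its nearest neighbour, and the gap between them lies beyond the scatter. The two structures differ in more than one place, so no single step between them can be read off, and no cause for the gap is assigned.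

Compound 3 `CC(C)c1c(C(=O)N(C)Cc2cccc(F)c2)nn(-c2ccc(F)cc2)c1OC[C@@H](O)C[C@@H](O)CC(=O)O` is the next compound. (3-fluorobenzyl)(methyl)amino in place of 2-phenylpyrrolidin-1-yl on a carbonyl carbon

Compound 3 carries an amide of the same open-chain type as compound 1, which in this assay gives 6.2 nM, while the rest of its core matches compound 2. Within the data shown here, no measured step isolates the amide change, so the expectation rests on the two values alone. The step from compound 2 to compound 3 is expected to be a modest move toward a lower number, a 1.8-fold lower number from compound 2 to compound 3 (0.24 log units; within the scatter), about halfway to the value of compound 1, with a range wide enough to include no change. Compound 3 is therefore estimated at 8 nM, expected between 3 nM and 25 nM.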

Compound 3, half-maximal inhibitory concentration: 14 nM
Estimate against measurement, compound 3: 1.8-fold (0.24 log units) below; low and high end bracket the measured number.
By their numbers in this assay, from the lowest: compound 1; then compounds 2 and 3 (each within the scatter of the next).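

At the carbonyl carbon, this assay shows no change at the digits printed from compound 2 to compound 3 (within the scatter) when (3-fluorobenzyl)(methyl)amino takes the place of 2-phenylpyrrolidin-1-yl. On this shared core, the position therefore accepts the open-chain amine in place of the one with a five-membered non-aromatic ring, while a six-membered aromatic ring of carbon only is present on both sides of the step and no hydrogen-bond donor or acceptor is counted on either group. No available measurement explains why the two groups give the same printed value.

The step changes the ring and introduces fluorine together, so the contribution of each remains unresolved, and the differences between compound 1 and the other two compounds span more than one place and cannot be read as steps. As far as these compounds go, whether unsubstituted benzyl(methyl)amino, a piperidine ring or a carboxylic acid on the benzyl ring would keep the value of compound 3 at this carbonyl carbon remains open.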